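A few compounds are considered here, and "the series" means these few. Any claim that something is new, unique, unknown or untested is made for them only; others in the source may bear on it.

Notes on the series in an ADME assay on MT4 cells (Homo sapiens) for cytotoxicity, read by MTT assay, with a stated time of 96 h; on this read-out higher numbers stand for lower toxicity in this test and lower numbers for higher toxicity in this test. Compound 1 `NS(=O)(=O)c1ccc(N2N=C(c3ccc(OCc4ccccc4)cc3)CC2c2ccc(F)cc2)cc1` reports only a limit, > 100000 nM. Compound 3 `NS(=O)(=O)c1ccc(N2N=C(c3ccc(OCc4ccccc4)cc3)CC2c2cccc(F)c2)cc1` gives 65000 nM. Compound 2 `NS(=O)(=O)c1ccc(N2N=C(c3ccc(Oc4ccccc4)cc3)CC2c2cccc(F)c2)cc1` gives 25000 nM, the lower of the two exact numbers. The next structure is compound 4 `NS(=O)(=O)c1ccc(N2N=C(c3ccc(Oc4ccccc4)cc3)CC2c2ccc(Cl)cc2)cc1`, with 4-chlorophenyl in place of 3-fluorophenyl on a saturated ring carbon.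

Among the measured compounds shown here, no measured step replaces fluorine with chlorine, so the support is indirect. The closest step is an at least 1.5-fold lower number from compound 1 to compound 3 (0.18 log units; that floor lies within the scatter), with 3-fluorophenyl in place of 4-fluorophenyl at the same place. Its floor lies within the scatter, so it gives only a weak hint that a 4-substituted phenyl does not lower the number. The other step, a 2.6-fold higher number from compound 2 to compound 3 (0.41 log units; beyond the scatter), is a change elsewhere, benzyl in place of phenyl on an oxygen on an aromatic ring, and it shows that single changes here can be modest in size.

In this assay a small upward move is expected, estimated as a 1.3-fold higher number from compound 2 to compound 4 (0.11 log units; within the scatter). For compound 4 the estimated value is 32000 nM, with an expected range of 12000 nM to 85000 nM.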

Compound 4, half-maximal cytotoxic concentration: 9000 nM
Compound 4: middle estimate off by 3.6-fold (0.55 log units), on the high side, and the stated range ends above it.
By their numbers in this assay, from the lowest: compound 4; then compound 2; then compound 3. At a limit, above all of these: compound 1.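

In this assay, among the compounds shown here, 4-chlorophenyl in place of 3-fluorophenyl on a saturated ring carbon gives a 2.8-fold lower number from compound 2 to compound 4 (0.44 log units; beyond the scatter), the first step at this position that lies beyond the scatter. The earlier hint at this carbon, from a step whose floor lies within the scatter, was that a 4-substituted phenyl does not lower the number, whereas compound 4 shows that a 4-substituted phenyl can go with a lower number. Compound 1, which has 4-fluorophenyl at this carbon and benzyl on the oxygen, gives only a limit, > 100000 nM, and the earlier hint rests on that limit: the limit of > 100000 nM in this assay, at which 1 of the 4 values shown sits.

From the compounds shown here alone, the step changes both the halogen and its place on the ring, so the share of each stays open. Also open, going by these compounds, is what 3-chlorophenyl, or a phenyl bearing an amine or a carboxylic acid, would give at this carbon.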